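Swapping chloro for fluoro in compound 2

The compounds below may be only part of what the source reports. "The series", "measured", "known", "first", "only" and "open" are said of these compounds alone.

In an ADME assay on HEK-293T cells (Homo sapiens) for inhibition, read by CCK-8 assay, with a stated time of 48 h, tested at 20 uM (a higher number here means more inhibition of growth at the concentration tested, a lower number less inhibition of growth), compound 2 (`N#C/C(=C\c1ccccc1OS(=O)(=O)c1ccc(Cl)cc1)C(=O)Nc1nnc(Cc2ccc(F)cc2)s1`) gives 6% as the lower of two numbers, and compound 1 (`COc1ccc(S(=O)(=O)Oc2ccccc2/C=C(\C#N)C(=O)Nc2nnc(Cc3ccc(F)cc3)s2)cc1`) gives 20% as the higher. Compound 3 (`N#C/C(=C\c1ccccc1OS(=O)(=O)c1ccc(F)cc1)C(=O)Nc1nnc(Cc2ccc(F)cc2)s1`) carries fluoro in place of chloro on an aromatic carbon, para to a large group (fluoro in place of chloro on an aromatic carbon). For the measured compounds named here, the only measured step at hand (a number 14 percentage points lower from compound 1 to compound 2 (beyond the scatter)) put chloro in place of methoxy, a different exchange and so only a loose guide. One halogen replacing another is expected to move this assay less, with the estimated step (a number 4 percentage points higher from compound 2 to compound 3 (within the scatter)) slightly upward and inside the scatter. The estimate for compound 3 is 10% (expected range 0% to 22%).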

Compound 3, percent growth inhibition at one concentration: "not toxic" (no number reported)
The entry for compound 3 holds no number, so the estimate cannot be set against anything.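

In this assay, for the compounds shown here, compound 3 is recorded only as "not toxic", with no number, so no step from compound 2 to compound 3 can be read, and no supporting data bear on this result. Going by these compounds, how far fluoro and chloro at this place differ in growth inhibition stays open.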